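A few compounds are considered here, and "the series" means these few. Any claim that something is new, unique, unknown or untested is made for them only; others in the source may bear on it.

Measured so far:
compound 1, `Nc1ncnc2c1c(Oc1cc(Cl)ccn1)nn2C1CCC1` — 0.333 h
compound 2, `Nc1ncnc2c1c(Oc1cc(C(F)(F)F)ccn1)nn2C1CC1` — > 2.41 h
compound 3, `Nc1ncnc2c1c(Oc1cc(O)ccn1)nn2C1CCC(F)(F)CC1` — > 2.41 h

In an ADME assay on microsomes from liver (Homo sapiens) for metabolic stability, read by LC-MS, using NADPH, with a stated time of 10 min, tested at 10 uM (a higher number here means that the compound lasts longer, a lower number that the compound disappears faster), compound 1 gives 0.333 h, a number well short of the upper end of the assay. Compound 2 reaches > 2.41 h, which is a limit of the assay rather than a number. Compound 3 likewise stands at > 2.41 h, again a limit of the assay. Compound 2 thus sits at the limit of > 2.41 h in this assay, at which 2 of the 3 values shown sit, so its true half-life is known only to lie beyond that point, and no ordering between compound 2 and compound 3 can be drawn from the values shown.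

Compound 4, `Nc1ncnc2c1c(Oc1cc(C(F)(F)F)ccn1)nn2C1CCCCC1`, is the next compound to be measured in this assay. Relative to compound 2 the change is cyclohexyl in place of cyclopropyl on an aromatic nitrogen. Within the data shown here, no measured pair in this set differs in only this way, so the size of the step has no direct precedent. Compound 3, which also carries a six-membered ring on the same aromatic nitrogen, still sits at the limit, which argues against a large loss. Compound 4 is therefore expected to remain fairly stable, with a step from compound 2 of about an at least 1.5-fold lower number from compound 2 to compound 4 (0.17 log units; that floor lies within the scatter), possibly within the scatter. The estimate for compound 4 in this assay is 1.6 h, with a range from 0.6 h to 3 h.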

Compound 4, half-life: 0.55 h
Estimate against measurement, compound 4: 2.9-fold (0.46 log units) above, outside the stated range (below it).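

In this assay, among these compounds, the pair formed by compound 2 and compound 4 is the first in the set to differ in one place only, and putting cyclohexyl in place of cyclopropyl on the aromatic nitrogen gives an at least 4.3-fold lower number from compound 2 to compound 4 (0.64 log units; beyond the scatter). The group on this nitrogen is therefore not a silent position for the half-life: with everything else in the molecule held fixed, the larger carbon ring alone takes the compound off the limit of the assay and to a measured number. The true size of the step may be larger than printed, and it can be read only as a floor, because compound 2 stands at a limit and not at a number: the limit of > 2.41 h in this assay, at which 2 of the 4 values shown sit.

The compounds shown leave open whether cyclopentyl, an open chain such as isopropyl, or a six-membered ring holding an oxygen atom would follow cyclopropyl or cyclohexyl on this nitrogen. Compound 3 also carries a six-membered ring there, with two fluorine atoms on it, but it differs from compound 4 in the group on the other ring as well, so the two cannot be read as a single change.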